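From 2-nitrophenyl to 3-methylphenyl on a shared core

A few compounds are considered here, and "the series" means these few. Any claim that something is new, unique, unknown or untested is made for them only; others in the source may bear on it.

In a functional assay on HCT-116 cells (Homo sapiens) for inhibition, read by MTT assay, with a stated time of 72 h (on this read-out higher numbers stand for weaker inhibition and lower numbers for stronger inhibition), compound 1 `CC1=NN(c2ccccc2)C(=O)[C@]12C(=O)C=CC[C@H]2c1ccccc1[N+](=O)[O-]` gives 11200 nM. Its mirror image, compound 2 `CC1=NN(c2ccccc2)C(=O)[C@@]12C(=O)C=CC[C@@H]2c1ccccc1[N+](=O)[O-]`, gives 66800 nM, while compound 3 `CC1=NN(c2ccccc2)C(=O)[C@]12C(=O)C=CC[C@@H]2c1ccc(C)cc1` gives 5800 nM. Compound 1 therefore lies within the scatter of compound 3 and clearly under compound 2, which makes for a modest step of a 6.0-fold higher number from compound 1 to compound 2 (0.78 log units; beyond the scatter). That step, beyond the scatter, is the only measured one, and it comes with the fact that compounds 1 and 2 differ only in the configuration as drawn. It therefore gives no size for exchanging a group.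

The next compound, compound 4 `CC1=NN(c2ccccc2)C(=O)[C@]12C(=O)C=CC[C@H]2c1cccc(C)c1`, carries 3-methylphenyl in place of 2-nitrophenyl on a saturated ring carbon. For the measured compounds named here, with no direct precedent in this assay, the closest guide is compound 3 at 5800 nM, so a small shift towards a lower number is expected, though none beyond the scatter. The estimated change is a 1.6-fold lower number from compound 1 to compound 4 (0.20 log units; within the scatter). Compound 4 is expected at 7000 nM, with an estimated range from 2500 nM to 20000 nM.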

Compound 4, half-maximal inhibitory concentration: 9580 nM
The estimate for compound 4 lay 1.4-fold (0.14 log units) below the measured number; measured number inside the range.
By their numbers in this assay, from the lowest: compounds 3, 4 and 1 (each within the scatter of the next); then compound 2.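

In this assay, putting 3-methylphenyl in place of 2-nitrophenyl on this saturated ring carbon gives the first measured size for exchanging a group, a 1.2-fold lower number from compound 1 to compound 4 (0.07 log units; within the scatter). A group with hydrogen-bond acceptors thus gives way to one without any, yet at this position and with this drawn configuration the assay does not tell the two apart. For the compounds shown here, the only step so far beyond the scatter remains a 6.0-fold higher number from compound 1 to compound 2 (0.78 log units; beyond the scatter), and what sets that pair apart is: the fact that compounds 1 and 2 differ only in the configuration as drawn.

Still open, from the compounds shown here alone, is how this position responds to a different kind of group, such as an amine or a carboxylic acid on the aromatic ring, or a longer chain in its place. Also open, going by these compounds, is whether the mirror image of compound 4 would show a gap like the one seen for the mirror-image pair.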